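Removing a Fluorine From a Chromene Ester and Acid

This account rests on a few compounds, and the source may have more. Where it says the series, first, only, none or still open, it means among the compounds named here.

Compound 1 `CCOC(=O)C1=Cc2ccccc2OC1(OCc1cn(-c2ccc(F)cc2)nn1)C(F)(F)F` gives 8400 nM in a functional assay on HeLa cells (Homo sapiens) for inhibition, read by MTT assay, with a stated time of 24 h; on this read-out lower numbers stand for stronger inhibition and higher numbers for weaker inhibition. Compound 2 `CCOC(=O)C1=Cc2ccccc2OC1(OCc1cn(-c2ccccc2)nn1)C(F)(F)F` differs from it only by hydrogen in place of fluoro on an aromatic carbon. In this assay compound 2 reaches only a limit of the assay, > 150000 nM. The step is an at least 17-fold higher number from compound 1 to compound 2 (1.25 log units; beyond the scatter).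

Compound 3 `O=C(O)C1=Cc2ccccc2OC1(OCc1cc(-c2ccc(F)cc2F)no1)C(F)(F)F` has a different core; the difference between the core of compound 1 and the core of compound 3 is not broken down here. In this assay compound 3 also sits at a limit of the assay, > 150000 nM. Two of the three values thus share (the limit of > 150000 nM in this assay, at which 2 of the 3 values shown sit).

Compound 4 `O=C(O)C1=Cc2ccccc2OC1(OCc1cc(-c2ccc(F)cc2)no1)C(F)(F)F` is not yet measured and differs from compound 3 by hydrogen in place of fluoro on an aromatic carbon. This is the same kind of change as from compound 1 to compound 2, but the place differs: there the new hydrogen sat para to a large group, here it sits ortho to a large group and meta to a fluoro group. The step expected from compound 3 to compound 4 is an at least 1.2-fold lower number from compound 3 to compound 4 (0.09 log units; that floor lies within the scatter), an expectation resting on compound 3 giving only a limit, > 150000 nM. Compound 4 is therefore expected to give roughly 120000 nM in this assay.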

Compound 4, half-maximal inhibitory concentration: > 150000 nM
Compound 4 ended at the assay's limit; the forecaster's own chance of this, stated with the estimate: 60%; middle value at least 1.2-fold (0.09 log units) away from the limit.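

Compound 3 and compound 4 both sit at the same limit of this assay, so no step can be read between them: the limit of > 150000 nM in this assay, at which 3 of the 4 values shown sit.

The compounds shown leave open whether going from 2,4-difluorophenyl to 4-fluorophenyl changes inhibition at all, and whether the large step seen between compound 1 and compound 2 has any counterpart on the core of compound 3.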